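Chloro for Methyl at the Weak End of the Series

The source may report more compounds than this note shows. Statements on the series, on what has been measured and on what is new or still open speak of the compounds shown alone.

Within the data shown here, compound 2 `CCOC(=O)c1c(-c2cc3cc(OC)ccc3oc2=O)nn(-c2cccc(C)c2)c1C(=O)OCC` stands with the highest number of the two measured so far in a functional assay on A549 cells (Homo sapiens) for cytotoxicity, read by MTT assay, with a stated time of 48 h (on this read-out higher numbers stand for weaker inhibition and lower numbers for stronger inhibition), where compound 2 gives 102000 nM. Among the measured compounds shown here, its only neighbour, compound 1 `CCOC(=O)c1c(-c2cc3cc(OC)ccc3oc2=O)nn(-c2ccccc2)c1C(=O)OCC`, gives 35000 nM in this assay, and the single measured step, a 2.9-fold higher number from compound 1 to compound 2 (0.46 log units; beyond the scatter), separates the two. Compound 3 `CCOC(=O)c1c(-c2cc3cc(OC)ccc3oc2=O)nn(-c2cccc(Cl)c2)c1C(=O)OCC` has not yet been measured. It differs from compound 2 in one place: chloro in place of methyl on an aromatic carbon. For the measured compounds named here, the one measured step that touches this spot, a 2.9-fold higher number from compound 1 to compound 2 (0.46 log units; beyond the scatter), concerns the arrival of the methyl itself, not its exchange for another group, so it gives the size of a change at that carbon but not the size of this particular swap. Going by the values given here, no measured pair in this set exchanges methyl for chloro anywhere. On that basis compound 3 is expected to come out at 80000 nM in this assay, with a range from 30000 nM to 200000 nM. The corresponding step of a 1.3-fold lower number from compound 2 to compound 3 (0.11 log units; within the scatter) is therefore expected to lie within the scatter, with no direction asserted.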

Compound 3, half-maximal inhibitory concentration: 148000 nM
The estimate for compound 3 lay 1.9-fold (0.27 log units) below the measured number, and the stated range covers the measured number.
By their numbers in this assay, from the lowest: compound 1; then compounds 2 and 3 (each within the scatter of the next).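

In this assay, the exchange of methyl for chloro gives a 1.5-fold higher number from compound 2 to compound 3 (0.16 log units; within the scatter), so this swap on the aromatic carbon does not separate the two compounds, and the 3-methylphenyl and 3-chlorophenyl versions read as equivalent here. The second substituent also shows that the earlier change was not unique to methyl: chloro in place of hydrogen gives a 4.2-fold higher number from compound 1 to compound 3 (0.63 log units; beyond the scatter), which, like a 2.9-fold higher number from compound 1 to compound 2 (0.46 log units; beyond the scatter), lies beyond the scatter, so among these three compounds both groups at this carbon go with weaker inhibition than the unsubstituted phenyl of compound 1, and none of the three goes against this. Nothing available bears on why these numbers fall as they do.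

The compounds shown leave open whether this pattern extends beyond methyl and chloro to a group of another kind at the same carbon, such as an amine or a carboxylic acid. They also leave open whether methyl and chloro would stay within the scatter of each other on a different carbon of the ring, or on a core carrying something other than the two ethyl esters.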